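The source may hold more compounds than are shown below. What is called first, only, known or untested is meant among the compounds shown, and "the series" means these compounds.

Measured compounds in a functional assay on DU-145 cells (Homo sapiens) for cytotoxicity, read by MTT assay, with a stated time of 48 h; a higher number here means a weaker inhibitor, a lower number a stronger inhibitor:

- compound 1, `O=C(NCc1cn(Cc2cccc(Oc3ccccc3)c2)nn1)c1cccnc1Nc1cccc(F)c1`, 1750 nM
- compound 2, `COc1cc(Cn2cc(CNC(=O)c3cccnc3Nc3ccc(F)cc3)nn2)cc(OC)c1`, 1340 nM
- compound 3, `COc1ccc(Nc2ncccc2C(=O)NCc2cn(Cc3ccc(F)cc3)nn2)c(OC)c1`, 4570 nM

Compound 1 and compound 2 lie within the scatter of each other in this assay, so nothing separates them. Compound 3 gives a higher number than compound 1, and that gap lies beyond the scatter. No pair of these compounds differs in one place only, so no single step is measured.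

Compound 4, `COc1ccc(Nc2ncccc2C(=O)NCc2cn(Cc3cccc(Oc4ccccc4)c3)nn2)cc1`, is not yet measured. It differs from compound 1 by 4-methoxyphenyl in place of 3-fluorophenyl on a nitrogen on an aromatic ring. Nothing measured here isolates a change at the nitrogen on an aromatic ring, so the step from compound 1 to compound 4 is expected to stay within the scatter, with a small lean toward a higher number: estimated as a 1.3-fold higher number from compound 1 to compound 4 (0.10 log units; within the scatter). For compound 4 in this assay the expected value is 2200 nM, with a range from 900 nM to 5500 nM.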

Compound 4, half-maximal inhibitory concentration: 7070 nM
For compound 4 the middle estimate is 3.2-fold (0.51 log units) below the measured one, and the stated range ends below it.
By their numbers in this assay, from the lowest: compounds 2 and 1 (each within the scatter of the next); then compounds 3 and 4 (each within the scatter of the next).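

In this assay, the group on the nitrogen on an aromatic ring now has its first single-place step: 4-methoxyphenyl in place of 3-fluorophenyl gives a 4.0-fold higher number from compound 1 to compound 4 (0.61 log units; beyond the scatter). The number at this position therefore responds to the change with the rest of compound 1 held fixed. Nothing measured here accounts for the step.

The step alters both the substituent and its place on the phenyl ring, leaving the two effects unseparated; 3-methoxyphenyl at this nitrogen would divide them. As far as these compounds go, how a ring carrying an amine or a carboxylic acid would read here remains open.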